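This account rests on a few compounds, and the source may have more. Where it says the series, first, only, none or still open, it means among the compounds named here.

Measured in a functional assay on cells (Panel CNS (Carcinoma cell lines), Homo sapiens) for inhibition, read by sulforhodamine B assay, with a stated time of 48 h; on this read-out lower numbers stand for stronger inhibition of growth and higher numbers for weaker inhibition of growth:
compound 1 `CN1CCN(CCCOc2cccc3nc(Nc4ccc(Cl)c(C(F)(F)F)c4)ccc23)CC1`: 1650 nM
compound 2 `CC(C)c1ccc(Nc2ccc3c(OCCCN4CCN(C)CC4)cccc3n2)cc1`: 9250 nM
compound 3 `CN1CCN(CCCOc2cccc3nc(Nc4ccc(F)c(F)c4)ccc23)CC1`: 4100 nM

Compound 3 stands between the other two, with a 2.5-fold higher number from compound 1 to compound 3 (0.40 log units; beyond the scatter) and a 2.3-fold lower number from compound 2 to compound 3 (0.35 log units; beyond the scatter). Compound 4 `CN1CCN(CCCOc2cccc3nc(Nc4cccc(Cl)c4)ccc23)CC1` carries 3-chlorophenyl in place of 3,4-difluorophenyl on a nitrogen on an aromatic ring. Among the measured compounds shown here, no measured step makes this exact exchange. The measured exchanges on that nitrogen are all modest, the widest being a 5.6-fold higher number from compound 1 to compound 2 (0.75 log units; beyond the scatter). Compound 1, whose group also bears chlorine, gives 1650 nM, which tilts the expectation slightly downward. The expected change in this assay is small and within the scatter: a 1.2-fold lower number from compound 3 to compound 4 (0.07 log units; within the scatter). For compound 4 the estimated value is 3500 nM, with an expected range of 1700 nM to 7000 nM.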

Compound 4, concentration for 50% growth inhibition: 1890 nM
Compound 4: middle estimate off by 1.9-fold (0.27 log units), on the high side; the measured number falls inside the stated range.
By their numbers in this assay, from the lowest: compounds 1 and 4 (each within the scatter of the next); then compound 3; then compound 2.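

In this assay, 3-chlorophenyl on the nitrogen gives a 2.2-fold lower number from compound 3 to compound 4 (0.34 log units; beyond the scatter) and a 4.9-fold lower number from compound 2 to compound 4 (0.69 log units; beyond the scatter) while a 1.1-fold higher number from compound 1 to compound 4 (0.06 log units; within the scatter) shows no separation from 4-chloro-3-(trifluoromethyl)phenyl. The trifluoromethyl group is therefore not required to reach the number of compound 1, and the chlorine-bearing groups of compound 1 and compound 4 both give lower numbers than compound 2 and compound 3. Nothing available explains why 3-chlorophenyl gives a lower number than 3,4-difluorophenyl. Open, on these data alone, is whether chlorine itself matters, or whether bromine or a nitrile on the phenyl would give a similar number.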